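Swapping Trifluoromethyl for Methyl Next to the Ring Nitrogen

The source may hold more compounds than are shown below. What is called first, only, known or untested is meant among the compounds shown, and "the series" means these compounds.

Measured so far:
Compound 1, `CC(C)c1onc(-c2c(Cl)cccc2Cl)c1COc1ccc(N(C)C(=O)c2ccc(C(=O)O)cc2)c(C(F)(F)F)n1`: 235 nM
Compound 2, `CC(C)c1onc(-c2c(Cl)cccc2Cl)c1COc1ccc(NC(=O)c2ccc(C(=O)O)cc2)c(C(F)(F)F)n1`: 452 nM

In an assay on isolated protein for agonist activity at Bile acid receptor (Homo sapiens), read by FRET (a higher number here means that more compound is needed for the effect, a lower number that less compound is needed), compound 1 gives the lowest of these two numbers. Within the data shown here, its only neighbour is compound 2, and the step of a 1.9-fold higher number from compound 1 to compound 2 (0.28 log units; within the scatter) stays within the scatter. Compound 3, `Cc1nc(OCc2c(-c3c(Cl)cccc3Cl)noc2C(C)C)ccc1N(C)C(=O)c1ccc(C(=O)O)cc1`, differs from compound 1 by methyl in place of trifluoromethyl on an aromatic carbon, next to the ring nitrogen. Among the measured compounds shown here, no measured step touches this position; the single step known concerns the amide nitrogen and offers no guide. With nothing to point either way, the step of a 1.5-fold higher number from compound 1 to compound 3 (0.17 log units; within the scatter) is expected to stay within the scatter. Compound 3 is estimated at 350 nM, between 120 nM and 1000 nM.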

Compound 3, half-maximal effective concentration: 365 nM
Compound 3: the middle estimate sits 1.0-fold (0.02 log units) below what was measured; the range from low to high includes it.
By their numbers in this assay, from the lowest: compounds 1, 3 and 2 (each within the scatter of the next).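

In this assay, methyl can take the place of trifluoromethyl on this aromatic carbon, next to the ring nitrogen, with no change beyond the scatter (a 1.6-fold higher number from compound 1 to compound 3 (0.19 log units; within the scatter)). The position therefore accepts a group of 1 heavy atom as well as one of 4 heavy atoms, and the fluorine atoms are not needed to stay within the scatter here. No measurement explains this result.

Still open, as far as these compounds go, is whether a chlorine atom, a methoxy group or an amine at this position would also stay within the scatter. Whether the same swap behaves alike in the compound carrying the amide hydrogen is open too.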